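The compounds below may be only part of what the source reports. "The series", "measured", "known", "first", "only" and "open" are said of these compounds alone.

Compound 1 `COc1cc(OC)c2c(=O)cc(C(=O)Nc3ccc(-n4cccc4)cc3)[nH]c2c1` shows in a functional assay on UoC-B1 cells (Homo sapiens) for antiproliferative activity, with a stated time of 72 h (a higher number here means that more compound is needed for the effect, a lower number that less compound is needed), a value of 51800 nM. Compound 2 `COC(=O)c1cc(=O)c2cc(NC(=O)Nc3ccc(F)c(Cl)c3)ccc2[nH]1` gives only a limit in this assay, namely > 6350 nM, and no number. Compound 3 `COC(=O)c1cc(=O)c2cc(NC(=O)N[C@@H](C)c3cccc(OC)c3)ccc2[nH]1` likewise gives only a limit, > 25200 nM. Compound 2 thus stands at one of the two limits among the three values, as the limit of > 6350 nM in this assay, at which 1 of the 3 values shown sits, records. Compound 4 `COC(=O)c1cc(=O)c2cc(NC(=O)NCc3ccccc3)ccc2[nH]1` differs from compound 2 by benzyl in place of 3-chloro-4-fluorophenyl on an amide-type nitrogen. No measured step of this kind exists among these compounds, so the expected change, a step that the limit leaves unreadable from compound 2 to compound 4, is none beyond the scatter. Compound 4 is expected to give about 20000 nM, between 5000 nM and 80000 nM, most likely again only as a limit.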

Compound 4, half-maximal effective concentration: > 19500 nM
Compound 4: no number, only a limit (the forecaster's own chance of this, stated with the estimate: 70%); the middle value lies beyond the limit too.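

Going by these compounds alone, compound 2 and compound 4 each give only a limit in this assay, so no step between them can be read. The compounds shown leave open whether benzyl in place of 3-chloro-4-fluorophenyl on an amide-type nitrogen changes the value at all.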